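A few compounds are considered here, and "the series" means these few. Any claim that something is new, unique, unknown or untested is made for them only; others in the source may bear on it.

Measured compounds:
- compound 1, `CCn1nccc1-c1ccccc1NCC1=NCCN1`: < 100000 nM
- compound 2, `CC(C)n1nccc1-c1ccccc1NCC1=NCCN1`: < 100000 nM
- compound 3, `Cn1ccc(-c2ccccc2NCC2=NCCN2)n1`: 15.9 nM

All three were tested in an in vitro functional assay on cells (Fibroblast) for agonist activity at Alpha-1D adrenergic receptor (Homo sapiens); on this read-out lower numbers stand for an effect already at smaller amounts and higher numbers for an effect only at larger amounts of compound. For compound 1 the value < 100000 nM is a limit of the assay and not a number. For compound 2 the value < 100000 nM is likewise a limit and not a number. The step between them, a step that the two limits leave unreadable from compound 1 to compound 2, therefore cannot be read, as both ends sit at the limit of < 100000 nM in this assay, at which 2 of the 3 values shown sit. Compound 3 is the only one of the three with a real number, 15.9 nM. How the core of compound 3 differs from the core of compound 1 is not broken down here.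

The compound still to be measured is compound 4, `CCn1ccc(-c2ccccc2NCC2=NCCN2)n1`. It differs from compound 3 by methyl in place of hydrogen on a saturated chain carbon bound to an aromatic nitrogen. The same kind of change, (methyl in place of hydrogen on a saturated chain carbon bound to an aromatic nitrogen and a saturated chain carbon), is found from compound 1 to compound 2, but there the place is a saturated chain carbon bound to an aromatic nitrogen and a saturated chain carbon, whereas in compound 4 the carbon is bound only to an aromatic nitrogen, so it is the same kind of change, not the same.

Since the earlier step is unreadable, the expectation for compound 4 rests on compound 3 alone, with its value 15.9 nM, and on the small size of the added group. Compound 4 is expected to give about 40 nM, somewhere from 10 nM to 300 nM, an estimated step of a 2.5-fold higher number from compound 3 to compound 4 (0.40 log units; beyond the scatter).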

Compound 4, half-maximal effective concentration: < 100000 nM
Compound 4 was reported as a limit; the forecaster's own chance of this, stated with the estimate: 10%; the middle value lies beyond the limit too.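

In this assay compound 4 gives < 100000 nM, which is a limit of the assay and not a number. The step from compound 3 to compound 4 therefore cannot be read, and compound 4 joins compound 1 and compound 2 at the same limit: the limit of < 100000 nM in this assay, at which 3 of the 4 values shown sit.

The compounds shown leave open how far compound 4 really lies from compound 3, and whether compound 1, compound 2 and compound 4 differ from one another at all.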